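Swapping an Aromatic Ring for a Hydroxyl-Bearing Oxolane

This account rests on a few compounds, and the source may have more. Where it says the series, first, only, none or still open, it means among the compounds named here.

Compound 2 `Cc1cc(C)c(CN2CCc3c(Cl)cc(-c4c(C)noc4C)c(Cl)c3C2=O)c(=O)[nH]1` gives 3.1 in a physicochemical assay for lipophilicity, at pH 7.4 (on this read-out higher numbers stand for higher lipophilicity and lower numbers for lower lipophilicity), the highest of the two single numbers: compound 1 `Cc1cc(C)c(CN2CCc3c(Cl)cc([C@@H](C)CO)c(Cl)c3C2=O)c(=O)[nH]1` gives 2.5, and compound 3 `COC(c1cc(Cl)c2c(c1Cl)C(=O)N(Cc1c(C)cc(C)[nH]c1=O)CC2)C1CCOC1` gives 3; 3; 3; 3 (4 entries). Compound 4 `Cc1cc(C)c(CN2CCc3c(Cl)cc([C@H](CO)[C@H]4CCCO4)c(Cl)c3C2=O)c(=O)[nH]1` is not yet measured; it differs from compound 2 in one place: a group of 8 heavy atoms (6 carbon, 2 oxygen; one five-membered non-aromatic ring with 1 hetero atom) in place of a group of 7 heavy atoms (5 carbon, 1 nitrogen, 1 oxygen; one five-membered aromatic ring with 2 hetero atoms), on an aromatic carbon. Going by the values given here, the only step that bears on this is a number 0.60 log units higher from compound 1 to compound 2 (beyond the scatter), in which the same 3,5-dimethyl-1,2-oxazol-4-yl replaced a group carrying a hydroxyl; the change to compound 4 runs the other way, though the entering group is larger than 1-(hydroxymethyl)ethyl. A drop beyond the scatter is therefore expected, a number 0.40 log units lower from compound 2 to compound 4 (beyond the scatter), and compound 4 is estimated at 2.7, between 2.2 and 3.2.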

Compound 4, distribution coefficient: 2.1
Compound 4: middle estimate off by 0.60 log units, on the high side; measured number below the stated range.
By their numbers in this assay, from the lowest: compound 4; then compound 1; then compound 2.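

In (this assay), the entering group with its oxolane ring and hydroxyl on this aromatic carbon gives a clearly lower number than 3,5-dimethyl-1,2-oxazol-4-yl (a number 1.00 log units lower from compound 2 to compound 4 (beyond the scatter)). On the side chain, oxolan-2-yl in place of methyl also lowers the number (a number 0.40 log units lower from compound 1 to compound 4 (beyond the scatter)), so a larger group here does not bring a higher number in this pair. Nothing measured here explains either step. Going by these compounds, whether an amine or a carboxylic acid in place of the hydroxyl would shift the number remains open. So does the effect of the two defined stereocentres of the entering group.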